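Formate to acetate on the tertiary ester of compound 2

The source may hold more compounds than are shown below. What is called first, only, known or untested is meant among the compounds shown, and "the series" means these compounds.

Two esters of the shared core have been measured. Compound 1 `O=C(OC1(C(=O)Nc2ccc([N+](=O)[O-])cc2)CCCCC1)c1ccccc1I` carries a 2-iodophenyl group on the ester carbonyl carbon, and in a functional assay on MCF7 cells (Homo sapiens) for inhibition, read by MTT assay, with a stated time of 72 h (on this read-out higher numbers stand for weaker inhibition and lower numbers for stronger inhibition), compound 1 gives 619 nM. Within the data shown here, compound 2 `O=COC1(C(=O)Nc2ccc([N+](=O)[O-])cc2)CCCCC1` is the formate, and in this assay compound 2 gives 35.4 nM, the lowest of the two numbers so far; the only step bearing on it, a 17-fold lower number from compound 1 to compound 2 (1.24 log units; beyond the scatter), shows that the larger ester group goes with the higher number.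

Compound 3 `CC(=O)OC1(C(=O)Nc2ccc([N+](=O)[O-])cc2)CCCCC1` is the acetate. The change from compound 2 is methyl in place of hydrogen on a carbonyl carbon; it is a small change in the same part of the molecule that the step from compound 1 to compound 2 altered, and in the opposite sense, since a group re-enters where hydrogen stood. That step was large, but the group entering here is far smaller than the one that left there, so a small increase in the number, probably at or only a little beyond the scatter, is expected in this assay, that is a 1.7-fold higher number from compound 2 to compound 3 (0.23 log units; within the scatter). For compound 3 the estimate in this assay is 60 nM, with a range from 25 nM to 150 nM.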

Compound 3, half-maximal inhibitory concentration: 403 nM
Compound 3: the middle estimate sits 6.7-fold (0.83 log units) below what was measured; measured number above the stated range.
By their numbers in this assay, from the lowest: compound 2; then compounds 3 and 1 (each within the scatter of the next).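

In this assay, methyl in place of hydrogen on a carbonyl carbon accounts for an 11-fold higher number from compound 2 to compound 3 (1.06 log units; beyond the scatter) and so is a large step for the entry of a single carbon at this position, which the earlier pair could not show. The other step, a 1.5-fold lower number from compound 1 to compound 3 (0.19 log units; within the scatter), lies within the scatter, so methyl and 2-iodophenyl cannot be told apart here, and the gap first seen between compound 1 and compound 2 does not grade with the number of heavy atoms on the carbonyl carbon: compound 3 goes against any such trend, and among these three esters only the formate, compound 2, stands apart. Nothing measured here accounts for the separate place of the formate.

From the compounds shown here alone, whether hydrogen alone on this carbonyl carbon gives the low number remains open, and a longer chain such as ethyl or a branched one such as isopropyl would show whether the number stays level with compound 3 and compound 1. An amine on the same carbon, giving a carbamate, would test whether groups other than carbon-linked ones behave the same way.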